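The source may hold more compounds than are shown below. What is called first, only, known or untested is meant among the compounds shown, and "the series" means these compounds.

In a toxicity assay on Huh-7 cells (Homo sapiens) for cytotoxicity, with a stated time of 3 days (a higher number here means that more compound is tolerated, a lower number that less compound is tolerated), compound 1 `C[C@@]1(O)[C@H](O)[C@@H](CO)O[C@H]1n1cc(-c2ccccc2)c2c(N)ncnc21` gives only a limit, > 44000 nM. Compound 2 `COc1ccc(-c2cn([C@@H]3O[C@H](CO)[C@@H](O)[C@@]3(C)O)c3ncnc(N)c23)cc1` also gives only a limit, > 44000 nM. Compound 3 `C[C@@]1(O)[C@H](O)[C@@H](CO)O[C@H]1n1cc(-c2cccc3ccccc23)c2c(N)ncnc21` likewise stands at a limit, > 44000 nM, so it has no exact number. Compound 4 `C[C@@]1(O)[C@H](O)[C@@H](CO)O[C@H]1n1cc(-c2ccco2)c2c(N)ncnc21` carries furan-2-yl in place of naphthalen-1-yl on an aromatic carbon. The closest evidence is a step that the two limits leave unreadable from compound 1 to compound 3, followed by a step that the two limits leave unreadable from compound 2 to compound 3 and a step that the two limits leave unreadable from compound 1 to compound 2. None of these steps has a readable size, and the measurements show (the limit of > 44000 nM in this assay, at which 3 of the 3 values shown sit). No change beyond the usual scatter, in either direction, is therefore expected, and the estimated step is a number no higher from compound 3 to compound 4 (the limit leaves the size open). For compound 4 the estimate is 44000 nM, with an expected range of 20000 nM to 88000 nM.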

Compound 4, half-maximal cytotoxic concentration: 49600 nM
The estimate for compound 4 lay 1.1-fold (0.05 log units) below the measured number; measured number inside the range.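

The steps to compound 4 from compounds 1, 2 and 3 cannot be read, since those three compounds give only a limit: the limit of > 44000 nM in this assay, at which 3 of the 4 values shown sit. Going by these compounds, whether exchanging phenyl, 4-methoxyphenyl, naphthalen-1-yl and furan-2-yl changes the result in this assay remains open.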